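The compounds below may be only part of what the source reports. "The series", "measured", "known", "first", "only" and "open" are said of these compounds alone.

Series on a shared core. Compound 1 `CCOC(=O)c1c(-c2cccc(-c3ccccc3)c2)[nH]c2cc(OC)c(OC)cc2c1=O` carries phenyl; compound 2 `CCOC(=O)c1c(-c2cccc(OC)c2)[nH]c2cc(OC)c(OC)cc2c1=O` carries methoxy instead, the change being (methoxy in place of phenyl on an aromatic carbon). In an ADME assay on HEK293 cells (Homo sapiens) for cytotoxicity, read by luminescence, with a stated time of 72 h (on this read-out lower numbers stand for an effect already at smaller amounts and higher numbers for an effect only at larger amounts of compound), compound 1 gives > 22000 nM, a limit of the assay. In this assay compound 2 gives > 22000 nM, again a limit. The step that the two limits leave unreadable from compound 1 to compound 2 therefore cannot be read, since both values sit at the limit of > 22000 nM in this assay, at which 3 of the 3 values shown sit. Compound 3 `CCOC(=O)c1c(-c2cccc(-c3ccccc3)c2)[nH]c2cc(Cl)c(Cl)cc2c1=O` has a different core; how the two cores differ is not broken down here. In this assay compound 3 gives > 22000 nM, also a limit. Compound 4 `CCOC(=O)c1c(-c2cccc(OC)c2)[nH]c2cc(Cl)c(Cl)cc2c1=O` is not yet measured; it differs from compound 3 by methoxy in place of phenyl on an aromatic carbon, the same change as that from compound 1 to compound 2. Compound 4 is expected to show a step that the limit leaves unreadable from compound 3 to compound 4, resting on compound 3 at the limit of > 22000 nM in this assay, at which 3 of the 3 values shown sit, and on a step that the two limits leave unreadable from compound 1 to compound 2. Compound 4 is estimated at 30000 nM, within 15000 nM to 100000 nM.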

Compound 4, half-maximal effective concentration: > 22000 nM
Compound 4 gave a limit, no number (the forecaster's own chance of this, stated with the estimate: 85%); the middle value lies beyond the limit too.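

Within the data shown here, no step from compound 3 to compound 4 can be read in this assay, since both values are limits: the limit of > 22000 nM in this assay, at which 4 of the 4 values shown sit.
The compounds shown leave open whether methoxy in place of phenyl on an aromatic carbon changes this read-out on either core.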